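Replacing a methylphenyl with a dimethoxyphenyl on the ring nitrogen

The source may hold more compounds than are shown below. What is called first, only, known or untested is meant among the compounds shown, and "the series" means these compounds.

Measured so far:
Compound 1, `COc1ccccc1N1C(=O)CSC1C(=O)NCCCCc1ccccc1`: 60%
Compound 2, `Cc1cccc(N2C(=O)CSC2c2cccc(C(=O)NCCCCc3ccccc3)c2)c1`: 93%

Of the compounds shown here, two have been measured in a functional assay on MG-63 cells (Homo sapiens) for inhibition, read by CCK-8 assay, with a stated time of 72 h, tested at 1 uM; a lower number here means less inhibition, a higher number more inhibition at the concentration tested (going by the name of the read-out). Compound 1 `COc1ccccc1N1C(=O)CSC1C(=O)NCCCCc1ccccc1` gives 60% in this assay. Compound 2 `Cc1cccc(N2C(=O)CSC2c2cccc(C(=O)NCCCCc3ccccc3)c2)c1` gives 93% in this assay, the highest of the two numbers; its nearest neighbour is compound 1, which lies a good deal lower, a gap beyond the scatter. Among the compounds with values here, compound 1 and compound 2 differ in more than one place, so no single structural step links their two values.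

Compound 3 `COc1ccc(N2C(=O)CSC2c2cccc(C(=O)NCCCCc3ccccc3)c2)c(OC)c1` has not yet been measured. It differs from compound 2 in one place: 2,4-dimethoxyphenyl in place of 3-methylphenyl on an amide-type nitrogen in a ring. Within the data shown here, no measured pair shows the effect of such a change on this core, so the expectation rests on compound 2 alone. Because compound 2 stands at 93%, with little room above it, the step from compound 2 to compound 3 is expected to be small, most likely downward or none beyond the scatter, as a number 13 percentage points lower from compound 2 to compound 3 (beyond the scatter). Compound 3 is therefore estimated at 80%, in a range from 55% to 95%.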

Compound 3, a percentage reported as inhibition, at one concentration (the size of the read-out at that concentration, not a potency): 56%
For compound 3 the middle estimate is 24 percentage points above the measured one; the measured number falls inside the stated range.
By their numbers in this assay, from the lowest: compounds 3 and 1 (each within the scatter of the next); then compound 2.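

In this assay the group on the amide-type nitrogen in the ring clearly matters: 2,4-dimethoxyphenyl in place of 3-methylphenyl gives a number 37 percentage points lower from compound 2 to compound 3 (beyond the scatter) with the rest of the molecule unchanged. Compounds 1 and 2 differ in more than one place, so they could not show this; the new pair isolates the effect of this one position on the shared core. The entering group has more heavy atoms and two hydrogen-bond acceptors where the leaving group has none, but nothing available here ties the drop to either of these differences.

The change swaps the methyl group for two methoxy groups in a single step, so the compounds shown leave open whether one methoxy group alone, as in 4-methoxyphenyl, would give a similar drop or whether it takes both. They also leave open how the plain phenyl group, or a phenyl ring carrying an amine or a carboxylic acid, would compare with 3-methylphenyl at this position on the ring nitrogen.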